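The compounds below may be only part of what the source reports. "The series", "measured", "known", "first", "only" and "open" are said of these compounds alone.

Measured so far in a functional assay on LOX IMVI cells (Homo sapiens) for inhibition, read by sulforhodamine B assay, with a stated time of 48 h; on this read-out higher numbers stand for lower toxicity in this test and lower numbers for higher toxicity in this test:
- compound 1, `Nc1cc(N)c2nc(-c3ccccc3)c(Oc3ccc(Cl)c(Cl)c3)nc2c1`: 72400 nM
- compound 2, `CCOC(=O)[C@H](CCC(=O)O)NC(=O)c1ccc(Sc2nc3cc(N)cc(N)c3nc2-c2ccccc2)cc1`: < 100000 nM
- compound 3, `CCOC(=O)[C@H](CCC(=O)O)NC(=O)c1ccc(Oc2nc3cc(N)cc(N)c3nc2-c2ccccc2)cc1`: 57500 nM

Compound 1 carries the highest of the two numbers given in this assay; the nearest is compound 3, and the gap between the two falls within the scatter of this assay, so no order between them is claimed. For compound 2 this assay reports only a limit, not a number; see (the limit of < 100000 nM in this assay, at which 1 of the 3 values shown sits). Compound 2 and compound 3 differ only in the linking atom between the core and the benzamide, yet with one of them known only as a limit nothing is concluded from that pair.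

Compound 4, `Nc1cc(N)c2nc(-c3ccccc3)c(Sc3ccc(Cl)c(Cl)c3)nc2c1`, is not yet measured in this assay. It differs from compound 1 in one place: (3,4-dichlorophenyl)sulfanyl in place of 3,4-dichlorophenoxy on an aromatic carbon, that is, a (3,4-dichlorophenyl)sulfanyl group replaces the 3,4-dichlorophenoxy group on an aromatic carbon of the core. Among the compounds with values here, no measured step of this kind is available, so the size of the move is expected to be small, with a slight lean toward a lower number, and nothing clearly beyond the scatter; the expected step is a 1.2-fold lower number from compound 1 to compound 4 (0.08 log units; within the scatter). Compound 4 is therefore estimated at 60000 nM, with a range from 25000 nM to 140000 nM.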

Compound 4, concentration lethal to 50% of the cells: 72400 nM
Estimate against measurement, compound 4: 1.2-fold (0.08 log units) below; measured number inside the range.
By their numbers in this assay, from the lowest: compounds 3, 1 and 4 (each within the scatter of the next).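

In this assay, within the data shown here, replacing 3,4-dichlorophenoxy with (3,4-dichlorophenyl)sulfanyl on the aromatic carbon next to the ring nitrogen gives the first readable step at this position: no change at the digits printed from compound 1 to compound 4 (within the scatter). With the rest of the structure unchanged, this read-out does not separate the oxygen-linked and sulfur-linked forms, a statement that holds for this one pair and for no wider set. The same exchange of linking atom also separates compound 3 and compound 2, which carry the benzamide side chain, but that pair still cannot be read, as the entry for compound 2 is a limit and not a number: the limit of < 100000 nM in this assay, at which 1 of the 4 values shown sits.

On these data alone, whether the lack of change seen with the dichlorophenyl group carries over to the benzamide side chain remains open, and a numerical value for compound 2 would be needed to settle it. Also open, as far as these compounds go, is what happens at this carbon with a methylene or an amine as the linking atom, or with a plain phenyl or a single chlorine in place of the 3,4-dichloro pattern on the ring.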